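Swapping Chloro for Amino: Expected Growth Inhibition of Compound 4

The source may report more compounds than this note shows. Statements on the series, on what has been measured and on what is new or still open speak of the compounds shown alone.

Of the compounds shown here, three have been tested in a functional assay on UACC-257 cells (Homo sapiens) for cytotoxicity, read by sulforhodamine B assay, with a stated time of 48 h; on this read-out higher numbers stand for weaker inhibition of growth and lower numbers for stronger inhibition of growth. Compound 3 `ClCc1ccc(Cn2cnc3c(Cl)nc(Cl)nc32)cc1` gives 16200 nM, and compound 1 `Nc1nc(Cl)c2ncn(Cc3ccc(CCl)cc3)c2n1` gives 12600 nM. Compound 1 differs from compound 3 by amino in place of chloro on an aromatic carbon, and this change gave a 1.3-fold lower number from compound 3 to compound 1 (0.11 log units; within the scatter). Compound 2 `ClCc1cccc(Cn2cnc3c(Cl)nc(Cl)nc32)c1` gives 1860 nM, the lowest of the three numbers and beyond the scatter from both others. Compound 2 and compound 3 are built from the same atoms joined differently; the difference between their cores is not broken down here.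

Compound 4 `Nc1nc(Cl)c2ncn(Cc3cccc(CCl)c3)c2n1` has not yet been measured in this assay. It differs from compound 2 by amino in place of chloro on an aromatic carbon, the same change that turned compound 3 into compound 1; among these compounds the change occurs twice in all. Compound 4 is expected to stay close to compound 2 in this assay, because the earlier instance of the change gave a 1.3-fold lower number from compound 3 to compound 1 (0.11 log units; within the scatter). Compound 4 is therefore expected to show a 1.2-fold lower number from compound 2 to compound 4 (0.09 log units; within the scatter). The estimate for compound 4 is 1500 nM, with a range from 700 nM to 3500 nM.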

Compound 4, concentration for 50% growth inhibition: 5750 nM
Compound 4: the middle estimate sits 3.8-fold (0.58 log units) below what was measured; the whole stated range lies below it.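

In this assay, amino in place of chloro on an aromatic carbon gave a 3.1-fold higher number from compound 2 to compound 4 (0.49 log units; beyond the scatter), so on the core of compound 2 this change weakened growth inhibition, if only modestly. The change therefore did not carry over unchanged from one core to the other: the same change on two cores in this assay, a 1.3-fold lower number (0.11 log units; within the scatter) from compound 3 to compound 1 and a 3.1-fold higher number (0.49 log units; beyond the scatter) from compound 2 to compound 4, 4.0-fold (0.60 log units) apart, beyond the scatter of two such steps

Among these compounds, this shows that a step read on one of these cores cannot simply be transferred to the other, even though the two cores are built from the same atoms joined differently, but with only two pairs it does not show what in the cores sets the steps apart or how the change would behave on a further core.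

The compounds shown leave open how a methylamino or a methoxy group would behave in the place of the amino group on these two cores. They also leave open whether the gap between the steps would remain if a hydroxymethyl group stood in the place of the chloromethyl group.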